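A methyl group on a compound at the limit

The source may hold more compounds than are shown below. What is called first, only, known or untested is meant among the compounds shown, and "the series" means these compounds.

Measured in a toxicity assay on THP-1 cells (Homo sapiens) for cytotoxicity, read by MTT assay; on this read-out lower numbers stand for stronger inhibition of growth and higher numbers for weaker inhibition of growth:
Compound 1 `C/C(=N\NC(N)=S)c1sc(-c2ccccc2)nc1C` gives 81.5 ug/mL
Compound 2 `C/C(=N\Nc1nc(-c2ccccc2)cs1)c1sc(C)nc1C` gives > 100 ug/mL, which is a limit
Compound 3 `C/C(=N\Nc1nc(-c2ccc(Cl)cc2)cs1)c1sc(C)nc1C` gives > 100 ug/mL, which is a limit

Compound 2 stands at the limit of > 100 ug/mL in this assay, at which 2 of the 3 values shown sit. Only compound 1 has a number. Compound 4 `C/C(=N\Nc1nc(-c2ccc(C)cc2)cs1)c1sc(C)nc1C` differs from compound 2 by methyl in place of hydrogen on an aromatic carbon. Within the data shown here, the one measured change of this kind, chloro in place of hydrogen on an aromatic carbon, is a step that the two limits leave unreadable from compound 2 to compound 3. It therefore gives no size to carry over, and no shift beyond the scatter is expected in this assay. The expected step is a step that the limit leaves unreadable from compound 2 to compound 4. For compound 4 the estimated value is 110 ug/mL, with an expected range from 60 ug/mL to 200 ug/mL. A report as a limit is the likeliest outcome.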

Compound 4, concentration for 50% growth inhibition: > 100 ug/mL
Compound 4 gave a limit, no number; the forecaster's own chance of this, stated with the estimate: 75%; the middle value does not contradict the limit.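

Among these compounds, compound 2, compound 3 and compound 4 each gave only a limit, so no step among them can be read: the limit of > 100 ug/mL in this assay, at which 3 of the 4 values shown sit. The compounds shown leave open whether methyl or chloro in place of hydrogen changes growth inhibition at all.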